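This account rests on a few compounds, and the source may have more. Where it says the series, first, only, none or still open, it means among the compounds named here.

Compound 3 `Cc1cc(C(=O)c2cccc(Br)c2)ccc1OCC(=O)Nc1nc(-c2ccccc2)cs1` gives 21700 nM in a functional assay on DLA cells (Mus musculus) for cytotoxicity, read by trypan blue exclusion, with a stated time of 48 h (a lower number here means a stronger inhibitor, a higher number a weaker inhibitor), a number that sits with those of compound 1 `Cc1cc(C(=O)c2ccccc2)ccc1OCC(=O)Nc1nc(-c2ccccc2)cs1` at 21500 nM and compound 2 `Cc1cc(C(=O)c2ccc(F)cc2)ccc1OCC(=O)Nc1nc(-c2ccccc2)cs1` at 32100 nM, all three within the scatter of one another. Compound 4 `Cc1cc(C(=O)c2ccccc2F)ccc1OCC(=O)Nc1nc(-c2ccccc2)cs1` differs from compound 3 by 2-fluorophenyl in place of 3-bromophenyl on a carbonyl carbon. The measured steps that change the ring on the same carbonyl carbon bear on this: a 1.5-fold higher number from compound 1 to compound 2 (0.17 log units; within the scatter), a 1.0-fold higher number from compound 1 to compound 3 (0.00 log units; within the scatter) and a 1.5-fold lower number from compound 2 to compound 3 (0.17 log units; within the scatter), each of them within the scatter. On that basis no step beyond the scatter is expected in this assay, and the estimated step is a 1.1-fold higher number from compound 3 to compound 4 (0.04 log units; within the scatter). Compound 4 is therefore expected to give 24000 nM, with a range from 12000 nM to 48000 nM.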

Compound 4, half-maximal inhibitory concentration: 13700 nM
For compound 4 the middle estimate is 1.8-fold (0.24 log units) above the measured one; low and high end bracket the measured number.
By their numbers in this assay, from the lowest: compounds 4, 1, 3 and 2 (each within the scatter of the next, the first and the last beyond it).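

In this assay, among these compounds, exchanging one fluorophenyl group for the other gives a 2.3-fold lower number from compound 2 to compound 4 (0.37 log units; beyond the scatter) and is the first step beyond the scatter at this position, though a modest one. By contrast a 1.6-fold lower number from compound 1 to compound 4 (0.20 log units; within the scatter) and a 1.6-fold lower number from compound 3 to compound 4 (0.20 log units; within the scatter) stay within the scatter, so only the two fluorophenyl compounds are told apart here. Nothing measured here explains that difference.

The compounds shown leave open how an amine or a carboxylic acid on this ring would read. They also leave open whether a larger step is possible at this position at all.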